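This account rests on a few compounds, and the source may have more. Where it says the series, first, only, none or still open, it means among the compounds named here.

Compound 1 `O=S(=O)(/C=C/c1ccccc1)Cc1ccc(Nc2ncnc3ccccc23)cc1`: > 100000 nM
Compound 2 `O=S(=O)(/C=C/c1ccc(F)cc1)Cc1ccc(Nc2ncnc3ccccc23)cc1`: 1000 nM

In a functional assay on PC-3 cells (Homo sapiens) (on this read-out lower numbers stand for stronger inhibition of growth and higher numbers for weaker inhibition of growth), compound 1 gives > 100000 nM, which is a limit of the assay and not a number: the limit of > 100000 nM in this assay, at which 1 of the 2 values shown sits. Among the measured compounds shown here, compound 2, at 1000 nM, therefore holds the only actual number in this small set. The next compound, compound 3 `N#Cc1ccc(/C=C/S(=O)(=O)Cc2ccc(Nc3ncnc4ccccc34)cc2)cc1`, has cyano in place of fluoro on an aromatic carbon. The change lies on a six-membered aromatic ring of carbon only, para to a large group.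

For the measured compounds named here, one measured step bears on it. This is an at least 100-fold lower number from compound 1 to compound 2 (2.00 log units; beyond the scatter), a large step beyond the scatter, made at the same place on the ring. That step replaced hydrogen, however, and so it says nothing direct about exchanging fluoro for cyano. Going by the values given here, since compound 3 also carries a group at that place, it is expected to stay in the region of compound 2 at 1000 nM, with no firm direction and no step clearly beyond the scatter. The expected change is a 1.5-fold higher number from compound 2 to compound 3 (0.18 log units; within the scatter). Given how steep the one measured step is, the uncertainty is wide. For compound 3 the estimated value is 1500 nM, with an expected range from 200 nM to 10000 nM.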

Compound 3, concentration for 50% growth inhibition: > 100000 nM
Compound 3: a limit, no number; the forecaster's own chance of this, stated with the estimate: 10%; middle value at least 66-fold (1.82 log units) from the limit.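

In this assay, exchanging fluoro for cyano at this place on the ring gives an at least 100-fold higher number from compound 2 to compound 3 (2.00 log units; beyond the scatter), so the result depends on which group is present and not merely on hydrogen being replaced. Compound 1 and compound 3 both rest at a limit of the assay and not at a number, so the step between them cannot be read: the limit of > 100000 nM in this assay, at which 2 of the 3 values shown sit. Of the three groups shown at this place, hydrogen, fluoro and cyano, only fluoro gives an actual number, so this position is far from indifferent to the group it carries, and the gain seen with fluoro does not carry over to cyano.

With a single actual number in the set, the compounds shown cannot say whether fluoro is an isolated case or one of several groups that work here, as chloro, methoxy or an amine at the same place could show. They also leave open whether the 4-fluorophenyl result holds when the ethenyl link or the shared core is changed, and how far compound 2 can be improved from its present value of 1000 nM.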